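Fluoro to Chloro on the Amide-Bearing Ring

The source may report more compounds than this note shows. Statements on the series, on what has been measured and on what is new or still open speak of the compounds shown alone.

Measured so far:
compound 1, `Cc1ccc(C)c(NC(=O)CSc2nnc(-c3ccoc3C)n2Cc2ccco2)c1`: 398 nM
compound 2, `Cc1occc1-c1nnc(SCC(=O)Nc2cccc(F)c2)n1Cc1ccco1`: 501 nM

In a functional assay on CHO cells for antagonist activity at Orexin receptor type 2 (Homo sapiens), read by FLIPR and calcium flux (a higher number here means a weaker inhibitor, a lower number a stronger inhibitor), compound 1 gives 398 nM, and compound 2 gives 501 nM. Compound 2 carries the higher of the two numbers, but the step of a 1.3-fold higher number from compound 1 to compound 2 (0.10 log units; within the scatter) lies within the scatter, so the two compounds cannot be told apart on these data.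

Compound 3, `Cc1occc1-c1nnc(SCC(=O)Nc2cccc(Cl)c2)n1Cc1ccco1`, differs from compound 2 by chloro in place of fluoro on an aromatic carbon. Among the measured compounds shown here, no measured step touches this halogen; the only step available, a 1.3-fold higher number from compound 1 to compound 2 (0.10 log units; within the scatter), exchanged the whole ring on the amide nitrogen and stayed within the scatter. That gives little reason to expect a shift beyond the scatter here. Compound 3 is therefore expected to land close to compound 2, and the expected step of a 1.3-fold lower number from compound 2 to compound 3 (0.10 log units; within the scatter) is small. The estimate for compound 3 in this assay is 400 nM, with a range from 150 nM to 1300 nM.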

Compound 3, inhibition constant: 63.1 nM
Compound 3: the middle estimate sits 6.3-fold (0.80 log units) above what was measured, and the stated range ends above it.
By their numbers in this assay, from the lowest: compound 3; then compounds 1 and 2 (each within the scatter of the next).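

In this assay the exchange of one halogen on the ring carried by the amide nitrogen gives a 7.9-fold lower number from compound 2 to compound 3 (0.90 log units; beyond the scatter) and lies beyond the scatter, so this position responds to a change of a single atom. The earlier pair could not show this, since its ring exchange stayed within the scatter. Against the 2,5-dimethylphenyl ring, the 3-chlorophenyl ring now stands apart as well, with a 6.3-fold lower number from compound 1 to compound 3 (0.80 log units; beyond the scatter) as the step. Nothing measured here explains why chloro and fluoro differ at this position.

These compounds leave open whether bromo or trifluoromethyl in the same place would follow chloro or fall back towards fluoro. They also leave open whether the effect of chloro would hold if another part of the shared core were changed.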